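Aryl replacement for the ether substituent at the lactam carbon

The source may hold more compounds than are shown below. What is called first, only, known or untested is meant among the compounds shown, and "the series" means these compounds.

For the measured compounds named here, compound 2 `Cc1noc(C)c1COC1CC(=O)Nc2c1c(C)nn2-c1ncnc2nc[nH]c12` gives 5 nM in a functional assay on HEK293 cells for agonist activity at G-protein coupled receptor 39 (Homo sapiens), read by scintillation proximity assay and inositol phosphate accumulation, with a stated time of 75 min, in the presence of a further agent that is not named here (a lower number here means that less compound is needed, a higher number that more compound is needed for the effect), the highest of the three numbers measured so far. Compound 1 `Cc1nn(-c2ncnc3nc[nH]c23)c2c1C(OC1CCCC1)CC(=O)N2` gives 2 nM and compound 3 `Cc1nn(-c2ncnc3nc[nH]c23)c2c1C(OCc1cc(F)cc3c1OCOC3)CC(=O)N2` gives 1.5 nM, both lower and beyond the scatter relative to compound 2.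

Compound 4 `Cc1nn(-c2ncnc3nc[nH]c23)c2c1C(c1ccc(OC(C)C)cc1)CC(=O)N2` differs from compound 2 in one place: 4-isopropoxyphenyl in place of (3,5-dimethyl-1,2-oxazol-4-yl)methoxy on a saturated ring carbon. The substituent at this position has been varied twice already. The step of a 2.5-fold higher number from compound 1 to compound 2 (0.40 log units; beyond the scatter) shows that exchanging one ether substituent for another moves the number by a modest amount, and the step of a 3.3-fold lower number from compound 2 to compound 3 (0.52 log units; beyond the scatter) shows a modest movement in the other direction. Going by the values given here, neither step removes the oxygen link to the ring carbon, so the change to a directly attached aryl group has no direct precedent here. Given that both other substituents at this position give lower numbers than compound 2, a modest lowering is expected, with wide uncertainty. Compound 4 is therefore expected to give 3 nM in this assay, between 1 nM and 12 nM, an expected step of a 1.7-fold lower number from compound 2 to compound 4 (0.22 log units; within the scatter).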

Compound 4, half-maximal effective concentration: 18 nM
Beside the measured number, compound 4's estimate is 6.0-fold (0.78 log units) below it, outside the stated range (above it).
By their numbers in this assay, from the lowest: compounds 3 and 1 (each within the scatter of the next); then compound 2; then compound 4.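

In this assay, placing 4-isopropoxyphenyl directly on the saturated ring carbon raises the number relative to both ethers it can be read against (a 3.6-fold higher number from compound 2 to compound 4 (0.56 log units; beyond the scatter); a 9.0-fold higher number from compound 1 to compound 4 (0.95 log units; beyond the scatter)), and both steps are beyond the scatter. All earlier compounds kept the oxygen on this carbon and their steps ran in both directions, whereas this first directly attached aryl group gives the highest of the four numbers, so the position does not accept every substituent equally. Nothing measured here accounts for the rise.

Open, from the compounds shown here alone, is whether the higher number follows from the missing oxygen link or from the 4-isopropoxy group itself, since a single aryl compound cannot separate the two. A plain phenyl, or a phenyl carrying an amine or a carboxylic acid in place of the isopropoxy group, would test that.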